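A few compounds are considered here, and "the series" means these few. Any claim that something is new, unique, unknown or untested is made for them only; others in the source may bear on it.

Compound 1, `O=C(Nc1cccc(-c2oc3cc(-c4ccc(F)cc4)ccc3c(=O)c2O)c1)c1ccc(F)cc1F`: 20500 nM
Compound 2, `O=C(Nc1cccc(-c2oc3cc(-c4ccc(F)cc4)ccc3c(=O)c2O)c1)c1ccc(Br)cc1`: 13500 nM
Compound 3, `CCc1ccc(C(=O)Nc2cccc(-c3oc4cc(-c5ccc(F)cc5)ccc4c(=O)c3O)c2)cc1`: 18500 nM

These three values come from a functional assay on A549 cells (Homo sapiens) for antiproliferative activity, read by CCK-8 assay, with a stated time of 72 h; a higher number here means a weaker inhibitor, a lower number a stronger inhibitor. The compounds share one core and differ only in the aryl group attached to the carbonyl carbon of the amide. Compound 2 has the smaller number of the three, but the step of a 1.5-fold lower number from compound 1 to compound 2 (0.18 log units; within the scatter) and the step of a 1.4-fold higher number from compound 2 to compound 3 (0.14 log units; within the scatter) both fall within the scatter, so compound 2 cannot be set apart from compound 1 or compound 3 on these numbers.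

Compound 4, `COc1cc(OC)cc(C(=O)Nc2cccc(-c3oc4cc(-c5ccc(F)cc5)ccc4c(=O)c3O)c2)c1`, is the next member of the series. Its change from compound 2 is 3,5-dimethoxyphenyl in place of 4-bromophenyl on a carbonyl carbon. The measured steps that bear on it are the three exchanges of the same aryl group: a 1.5-fold lower number from compound 1 to compound 2 (0.18 log units; within the scatter), a 1.1-fold lower number from compound 1 to compound 3 (0.04 log units; within the scatter) and a 1.4-fold higher number from compound 2 to compound 3 (0.14 log units; within the scatter), every one of them within the scatter. None of those exchanges brought in hydrogen-bond acceptors, which the new group does, so the measured steps do not cover this change fully. Still, on the evidence available, no step beyond the scatter is expected in this assay in either direction, and the expected step is a 1.1-fold higher number from compound 2 to compound 4 (0.05 log units; within the scatter). Compound 4 is therefore estimated at 15000 nM, with a range from 6000 nM to 40000 nM.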

Compound 4, half-maximal inhibitory concentration: 2390 nM
Estimate against measurement, compound 4: 6.3-fold (0.80 log units) above; measured number below the stated range.
By their numbers in this assay, from the lowest: compound 4; then compounds 2, 3 and 1 (each within the scatter of the next).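

In this assay, within the data shown here, the aryl group on the carbonyl carbon of the amide had so far seemed a place where exchanges changed little, but 3,5-dimethoxyphenyl breaks that picture, with a 5.6-fold lower number from compound 2 to compound 4 (0.75 log units; beyond the scatter), a 7.7-fold lower number from compound 3 to compound 4 (0.89 log units; beyond the scatter) and an 8.6-fold lower number from compound 1 to compound 4 (0.93 log units; beyond the scatter). The earlier groups, 2,4-difluorophenyl, 4-bromophenyl and 4-ethylphenyl, could not be told apart, so this position does respond to the aryl group, and compound 4 is the strongest inhibitor of the four, with steps to all the others beyond the scatter. The entering group has more heavy atoms than 4-bromophenyl, carries oxygen and hydrogen-bond acceptors where 4-bromophenyl has none, and has its substituents placed differently, and no measurement here ties the improvement to any one of these differences.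

The compounds shown leave open whether the methoxy groups themselves matter or only their arrangement on the ring, which ethoxy, hydroxyl or amine groups in their place could help to separate. They also leave open whether the same aryl group would give a similar improvement on other cell types, since all four numbers come from one cell line.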